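A few compounds are considered here, and "the series" means these few. Any claim that something is new, unique, unknown or untested is made for them only; others in the source may bear on it.

Compound 3 `CCC(=O)Nc1cc(C(=O)NC2CCC2)ccc1OC` stands at the edge of what this study can report. In an ADME assay on MDCK cells (Canis lupus familiaris) for cytotoxicity, read by cytopathic effect, with a stated time of 48 h (on this read-out higher numbers stand for lower toxicity in this test and lower numbers for higher toxicity in this test), compound 3 gives > 724 uM, which is a limit of the assay and not a number (the limit of > 724 uM in this assay, at which 1 of the 3 values shown sits). Compound 1 `CCC(=O)Nc1cc(C(=O)Nc2ccc(C)cc2)ccc1OC` gives 162 uM in this assay, and compound 2 `CCC(=O)Nc1cc(C(=O)Nc2cccc(Cl)c2)ccc1OC` gives 602 uM. The steps leading to compound 3 were an at least 4.4-fold higher number from compound 1 to compound 3 (0.65 log units; beyond the scatter) and an at least 1.2-fold higher number from compound 2 to compound 3 (0.08 log units; that floor lies within the scatter); both exchanged an aryl group on the amide-type nitrogen for cyclobutyl. Compound 4 `CCC(=O)Nc1cc(C(=O)Oc2ccccc2)ccc1OC` has not been measured. It differs from compound 3 by phenoxy in place of cyclobutylamino on a carbonyl carbon. The measured steps kept the amide-type nitrogen and only changed the group on it, so they bear on this new step only loosely. Still, compound 4 brings back a six-membered aromatic ring, and a downward step is expected, modest in size, because an at least 4.4-fold higher number from compound 1 to compound 3 (0.65 log units; beyond the scatter) placed the aryl compound 1 well below the cyclobutyl compound 3: an at least 1.8-fold lower number from compound 3 to compound 4 (0.25 log units; that floor lies within the scatter). Compound 4 is therefore estimated at 400 uM, within a range of 120 uM to 724 uM.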

Compound 4, half-maximal toxic concentration: 464 uM
Compound 4: middle estimate off by 1.2-fold (0.06 log units), on the low side; low and high end bracket the measured number.
By their numbers in this assay, from the lowest: compound 1; then compounds 4 and 2 (each within the scatter of the next). At a limit, above all of these: compound 3.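

Of the steps shown, this is the only one that takes away the nitrogen on the carbonyl carbon, and with it the amide hydrogen, and in this assay it reads as an at least 1.5-fold lower number from compound 3 to compound 4 (0.19 log units; that floor lies within the scatter). Compound 4 gives 464 uM and compound 2 gives 602 uM, values within the scatter of each other, so an ester link with phenoxy reads much like an amide link with 3-chlorophenyl. Compound 3 stands at a limit of the assay and not a number, so only a floor of this step can be read: the limit of > 724 uM in this assay, at which 1 of the 4 values shown sits.

The compounds shown leave open how phenylamino on this carbonyl carbon would compare with phenoxy, with the ring kept and only the linking atom changed. They also leave open how cyclobutoxy would compare with cyclobutylamino.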